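The compounds below may be only part of what the source reports. "The series", "measured", "known", "first", "only" and "open" are said of these compounds alone.

Compound 2 `O=c1[nH]c2cc[nH]c2c(=O)n1CCCN1CCN(c2ccccc2Cl)CC1` and compound 1 `COc1ccccc1N1CCN(CCCn2c(=O)[nH]c3cc[nH]c3c2=O)CC1` share one core and differ only in the group on the aromatic carbon of the outer ring. In an assay for binding affinity to Adrenergic receptor alpha-1 (Rattus norvegicus) (a lower number here means a stronger inhibitor, a higher number a weaker inhibitor), compound 1 gives 28 nM, and compound 2 gives 59.8 nM, the higher of the two numbers; the step of a 2.1-fold higher number from compound 1 to compound 2 (0.33 log units; beyond the scatter) is the only one measured. Compound 3 `Cc1ccc(-c2cc3[nH]c(=O)n(CCCN4CCN(c5ccccc5Cl)CC4)c(=O)c3[nH]2)cc1` carries 4-methylphenyl in place of hydrogen on an aromatic carbon. Among the compounds with values here, no measured step touches this position, so the earlier step offers no direct guide, and a modest weakening is the expectation for compound 3, with a 1.7-fold higher number from compound 2 to compound 3 (0.22 log units; within the scatter) in this assay. Compound 3 is therefore expected to give about 100 nM, most likely between 25 nM and 400 nM.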

Compound 3, inhibition constant: 110 nM
Estimate against measurement, compound 3: 1.1-fold (0.04 log units) below; measured number inside the range.
By their numbers in this assay, from the lowest: compound 1; then compounds 2 and 3 (each within the scatter of the next).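

Within the data shown here, the position on the aromatic carbon of the five-membered ring, next to the ring nitrogen, had carried only hydrogen in the earlier compounds. In this assay, placing a 4-methylphenyl group there gives a 1.8-fold higher number from compound 2 to compound 3 (0.26 log units; within the scatter), so this added ring of 7 heavy atoms leaves the two numbers indistinguishable. No supporting data explain this result.

From the compounds shown here alone, whether an amine or a carboxylic acid on that phenyl ring would keep the number within the scatter remains open. So does whether 4-methylphenyl would give a similar step alongside the methoxy group of compound 1.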